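Morpholine amide in place of bromopiperidine amide

A few compounds are considered here, and "the series" means these few. Any claim that something is new, unique, unknown or untested is made for them only; others in the source may bear on it.

Measured so far in an assay on isolated protein for inhibition of 15-hydroxyprostaglandin dehydrogenase [NAD(+)] (Homo sapiens), read by fluorescence, with a stated time of 15 min; on this read-out higher numbers stand for weaker inhibition and lower numbers for stronger inhibition:
compound 1 `c1ccc(-n2ccc(-c3nnc4n3CCCCC4)n2)cc1` gives 3830 nM
compound 2 `Cc1cccc(-n2cnc3cc(C(=O)N4CCC(Br)CC4)ccc32)c1` gives 76 nM
compound 3 `Cc1cccc(-n2cnc3cc(C(=O)N4CCC(C(F)(F)F)CC4)ccc32)c1` gives 1520 nM

Compound 2 stands at the lowest number of the three, with compound 3 nearest and compound 1 furthest, both beyond the scatter. For the measured compounds named here, the only single-point step measured is a 20-fold higher number from compound 2 to compound 3 (1.30 log units; beyond the scatter), a large upward move when the group on the saturated ring carbon of the 4-bromopiperidin-1-yl is exchanged.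

Compound 4 `Cc1cccc(-n2cnc3cc(C(=O)N4CCOCC4)ccc32)c1` has not been measured in this assay. It differs from compound 2 by morpholin-4-yl in place of 4-bromopiperidin-1-yl on a carbonyl carbon. Here the whole 4-bromopiperidin-1-yl group is exchanged rather than one substituent on it, so no measured step matches the change exactly; the step from compound 2 to compound 3 is the only guide, and it was large and upward. An upward step of comparable size is therefore expected, as a 20-fold higher number from compound 2 to compound 4 (1.30 log units; beyond the scatter). For compound 4 the estimate in this assay is 1500 nM, with a range of 300 nM to 7000 nM.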

Compound 4, half-maximal inhibitory concentration: 3040 nM
The estimate for compound 4 lay 2.0-fold (0.31 log units) below the measured number, and the stated range covers the measured number.
By their numbers in this assay, from the lowest: compound 2; then compounds 3, 4 and 1 (each within the scatter of the next, the first and the last beyond it).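

In this assay, the step of a 40-fold higher number from compound 2 to compound 4 (1.60 log units; beyond the scatter) shows that exchanging the whole 4-bromopiperidin-1-yl group on the carbonyl carbon, not only the bromo on it, also gives a large rise. With two different replacements now giving much higher numbers, the low number of compound 2 is not carried by the shared core and carbonyl alone, but depends on the 4-bromopiperidin-1-yl group. Compound 3 at 1520 nM and compound 4 at 3040 nM lie within the scatter of each other, so these two replacements cannot be told apart in this assay.

No supporting measurement bears on the origin of this rise. Still open, going by these compounds, is whether chloro, methyl or nitrile in place of the bromo on the saturated ring carbon would keep a number near that of compound 2.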